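Aryl urea variation on the shared core

The source may hold more compounds than are shown below. What is called first, only, known or untested is meant among the compounds shown, and "the series" means these compounds.

Going by the values given here, in a functional assay on CRL2813 cells (Homo sapiens) for cytotoxicity, read by sulforhodamine B assay, with a stated time of 5 days (a lower number here means a stronger inhibitor, a higher number a weaker inhibitor), compound 2 `O=C(Nc1ccc(I)cc1)N[C@H]1CC[C@H](Oc2ccc(F)cc2)CC1` gives 10200 nM, the lowest of the two numbers so far. Its nearest neighbour is compound 1 `O=C(Nc1ccccc1F)N[C@H]1CC[C@H](Oc2ccc(F)cc2)CC1`, which gives 17500 nM, and the step of a 1.7-fold lower number from compound 1 to compound 2 (0.23 log units; within the scatter). Compound 3 `COc1ccc(NC(=O)N[C@H]2CC[C@H](Oc3ccc(F)cc3)CC2)cc1` is not yet measured. It differs from compound 2 by methoxy in place of iodo on an aromatic carbon; cut one bond further out, the change reads 4-iodophenyl to 4-methoxyphenyl. Among the compounds with values here, only one measured step touches the aryl group of this urea, the exchange of 2-fluorophenyl for 4-iodophenyl, and that step, a 1.7-fold lower number from compound 1 to compound 2 (0.23 log units; within the scatter), stayed within the scatter. Nothing measured addresses a methoxy at this place, so there is no basis for expecting a step beyond the scatter in either direction. The expected step of a 1.4-fold higher number from compound 2 to compound 3 (0.14 log units; within the scatter) is therefore taken as small. Compound 3 is estimated at 14000 nM in this assay, with a range from 6000 nM to 35000 nM; the range is set somewhat wider on the low side because a 1.7-fold lower number from compound 1 to compound 2 (0.23 log units; within the scatter) moved the number downward when the aryl group last changed.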

Compound 3, half-maximal inhibitory concentration: > 20000 nM
Compound 3: only a limit was reported (the forecaster's own chance of this, stated with the estimate: 5%); at least 1.4-fold (0.15 log units) between middle value and limit.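

In this assay compound 3 gives > 20000 nM, which is a limit of the assay and not a number. Methoxy in place of iodo, on an aromatic carbon para to a large group, gives an at least 1.9-fold higher number from compound 2 to compound 3 (0.29 log units; that floor lies within the scatter), and 4-methoxyphenyl in place of 2-fluorophenyl gives an at least 1.1-fold higher number from compound 1 to compound 3 (0.05 log units; that floor lies within the scatter); both are floors, so the real gaps may be wider than they read, but neither floor by itself establishes a loss beyond the scatter. The earlier pair offered only a fully sized step within the scatter, whereas this aryl change is the first with no upper end, so the series now holds one open-ended reading at this place: the limit of > 20000 nM in this assay, at which 1 of the 3 values shown sits.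

On these data alone, what stays open is where the number for compound 3 really lies, and with it whether methoxy in place of iodo moves the read-out beyond the scatter at all. Also open, as far as these compounds go, is how an amine, a carboxylic acid or a longer chain such as ethoxy at this place would read against compound 2, which would show whether any group here brings the number clearly lower.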